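This account rests on a few compounds, and the source may have more. Where it says the series, first, only, none or still open, it means among the compounds named here.

In a functional assay on HepG2 cells (Homo sapiens) for antiproliferative activity, read by MTT assay (on this read-out lower numbers stand for stronger inhibition and higher numbers for weaker inhibition), compound 1 (`Cc1cccc(Nc2nccc(-c3ccc(Br)cc3)n2)c1`) gives 74600 nM. That lies within the scatter of compound 3 (`COc1cccc(Nc2nccc(-c3ccc(F)cc3)n2)c1`) at 128000 nM, and clearly higher than compound 2 (`Clc1ccc(Nc2nccc(-c3ccc(Cl)cc3Cl)n2)c(Cl)c1`) at 8080 nM. Within the data shown here, no two measured compounds differ in one place, so the series offers no direct measure of the change in question. Compound 4 (`Clc1ccc(Nc2nccc(-c3ccc(Br)cc3)n2)cc1`) departs from compound 1 as follows: 4-chlorophenyl in place of 3-methylphenyl on a nitrogen on an aromatic ring, with 4-chlorophenyl in place of 3-methylphenyl on a nitrogen on an aromatic ring. Of the measured compounds, only compound 2, at 8080 nM, has chlorine on the group at that nitrogen, which gives weak support for expecting a lower number. The expected step of a 2.5-fold lower number from compound 1 to compound 4 (0.40 log units; beyond the scatter) is modest, towards stronger inhibition. For compound 4 the estimate is 30000 nM, with an expected range of 10000 nM to 85000 nM.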

Compound 4, half-maximal inhibitory concentration: 47500 nM
Beside the measured number, compound 4's estimate is 1.6-fold (0.20 log units) below it, and the stated range covers the measured number.
By their numbers in this assay, from the lowest: compound 2; then compounds 4, 1 and 3 (each within the scatter of the next, the first and the last beyond it).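

In this assay, among these compounds, 4-chlorophenyl in place of 3-methylphenyl on a nitrogen on an aromatic ring gives a 1.6-fold lower number from compound 1 to compound 4 (0.20 log units; within the scatter) as the first one-place comparison. In this pair, the exchange of the methyl-bearing group for the chlorine-bearing one does not move the number beyond the scatter. Nothing on hand explains this result. Still open, as far as these compounds go, is whether an amine or a carboxylic acid on the phenyl ring at this nitrogen would shift the number beyond the scatter. Also open, from the compounds shown here alone, is how a longer chain there would read.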